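The source may hold more compounds than are shown below. What is called first, only, known or untested is meant among the compounds shown, and "the series" means these compounds.

Measured compounds:
Compound 1 `CC(=O)N1CCC(C)(C(=O)N2CC[C@](c3ccc(C(OCc4c(F)cccc4F)(C(F)(F)F)C(F)(F)F)cc3)(S(=O)(=O)c3ccc(F)cc3)C2)CC1`: 1%
Compound 2 `Cc1cccc(C)c1COC(c1ccc([C@]2(S(=O)(=O)c3ccc(F)cc3)CCN(C(=O)[C@H]3CC[C@H](C(=O)O)CC3)C2)cc1)(C(F)(F)F)C(F)(F)F`: 89%

Of the compounds shown here, two have been tested in an ADME assay on microsomes from liver (Homo sapiens) for metabolic stability, with a stated time of 10 min; on this read-out lower numbers stand for a less stable compound and higher numbers for a more stable compound. Compound 2 stands highest of the two numbers with 89%; the nearest, compound 1, is far lower at 1%, a gap well beyond the usual scatter of this assay. The two differ in several places at once, so their two values only show how far apart they lie and nothing more.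

The step followed here leads from compound 2 to compound 3 `COc1cccc(F)c1COC(c1ccc([C@]2(S(=O)(=O)c3ccc(F)cc3)CCN(C(=O)[C@H]3CC[C@H](C(=O)O)CC3)C2)cc1)(C(F)(F)F)C(F)(F)F`, which has not yet been tested in this assay. The structures differ in one place: 2-fluoro-6-methoxyphenyl in place of 2,6-dimethylphenyl on a saturated chain carbon bound to an oxygen on a saturated carbon. The rest of the molecule, including the shared core, is unchanged.

Going by the values given here, no step between two measured compounds isolates this change, so the expectation rests on compound 2 alone, which reads 89%. The step from the measured compound to its new partner is expected to be a modest drop, a number 14 percentage points lower from compound 2 to compound 3 (beyond the scatter), possibly within the scatter. Compound 3 is therefore estimated at 75%, with a range from 45% to 95%.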

Compound 3, percent of the compound remaining: 82%
For compound 3 the middle estimate is 7 percentage points below the measured one; measured number inside the range.
By their numbers in this assay, from the lowest: compound 1; then compounds 3 and 2 (each within the scatter of the next).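

In this assay, putting 2-fluoro-6-methoxyphenyl in place of 2,6-dimethylphenyl gives a number 7 percentage points lower from compound 2 to compound 3 (within the scatter), so this pair cannot be told apart on this read-out. Going by these compounds alone, this is the first comparison here in which only one place differs, and it shows that, for this pair, a group of carbon only on the saturated chain carbon bound to an oxygen can give way to one holding an oxygen and a fluorine, with 1 hydrogen-bond acceptor, without the reading leaving the usual scatter. Nothing measured here offers an explanation for this outcome.

Still open, as far as these compounds go, is how an unsubstituted phenyl or a 2,6-difluorophenyl group would read at this place, and whether the fluorine or the methoxy group alone would read like the two together. Also open, from the compounds shown here alone, is whether the same swap would stay within the scatter with a primary amide in place of the carboxylic acid that compound 2 and compound 3 share, since a single pair cannot show how far this result carries to other molecules.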